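Amine substituent change: sulfonamide back to amide

This account rests on a few compounds, and the source may have more. Where it says the series, first, only, none or still open, it means among the compounds named here.

In an in vitro assay on cells for binding affinity to myelin-associated glycoprotein (Mus musculus), read by surface plasmon resonance (a lower number here means tighter binding, a higher number weaker binding), compound 3 `CS(=O)(=O)N[C@H]1[C@H]([C@@H](O)[C@H](O)CNC(=O)c2ccc(Cl)cc2)O[C@@](OCc2cccc(F)c2F)(C(=O)O)C[C@@H]1O` gives 17000 nM, the highest number of the three measured; compound 1 `CC(=O)N[C@H]1[C@H]([C@@H](O)[C@H](O)CNC(=O)c2ccc(Cl)cc2)O[C@@](OCc2cccc(F)c2F)(C(=O)O)C[C@@H]1O` gives 2400 nM and compound 2 `O=C(NC[C@@H](O)[C@H](O)[C@@H]1O[C@@](OCc2cccc(F)c2F)(C(=O)O)C[C@H](O)[C@H]1NS(=O)(=O)c1ccccc1[N+](=O)[O-])c1ccc(Cl)cc1` gives 1400 nM. The steps into compound 3 were a 7.1-fold higher number from compound 1 to compound 3 (0.85 log units; beyond the scatter) and a 12-fold higher number from compound 2 to compound 3 (1.08 log units; beyond the scatter), whereas a 1.7-fold lower number from compound 1 to compound 2 (0.23 log units; within the scatter). Compound 4 `O=C(CC1CC1)N[C@H]1[C@H]([C@@H](O)[C@H](O)CNC(=O)c2ccc(Cl)cc2)O[C@@](OCc2cccc(F)c2F)(C(=O)O)C[C@@H]1O` carries (cyclopropylmethyl)carbonyl in place of methylsulfonyl on an amine nitrogen. Among the measured compounds shown here, this reverses the exchange of acyl for sulfonyl seen between compound 1 and compound 3, and at the same time puts a different alkyl on the carbonyl, a change for which no measured step exists. The number for compound 4 is therefore expected to return toward that of compound 1, an estimated 6.8-fold lower number from compound 3 to compound 4 (0.83 log units; beyond the scatter). Compound 4 is estimated at 2500 nM, with a range from 800 nM to 8000 nM.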

Compound 4, dissociation constant: 4100 nM
Compound 4: middle estimate off by 1.6-fold (0.21 log units), on the low side; measured number inside the range.
By their numbers in this assay, from the lowest: compounds 2, 1 and 4 (each within the scatter of the next, the first and the last beyond it); then compound 3.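

In this assay the methylsulfonyl group on the amine nitrogen gives way to (cyclopropylmethyl)carbonyl with a clear gain (a 4.1-fold lower number from compound 3 to compound 4 (0.62 log units; beyond the scatter)), though this group does not match the (2-nitrophenyl)sulfonyl group (a 2.9-fold higher number from compound 2 to compound 4 (0.47 log units; beyond the scatter)). Cyclopropyl on the acetyl chain is tolerated (a 1.7-fold higher number from compound 1 to compound 4 (0.23 log units; within the scatter)), so this position accepts more than acetyl among carbonyl groups. No supporting evidence bears on these differences. Open, as far as these compounds go, is whether a benzoyl group or a longer chain on the carbonyl holds up here, and whether a phenylsulfonyl group without the nitro group matches the (2-nitrophenyl)sulfonyl group.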